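A few compounds are considered here, and "the series" means these few. Any claim that something is new, unique, unknown or untested is made for them only; others in the source may bear on it.

In a functional assay on HeLa cells (Homo sapiens) for antiproliferative activity, read by MTT assay, with a stated time of 72 h (on this read-out higher numbers stand for weaker inhibition and lower numbers for stronger inhibition), compound 1 `COc1cc(-c2ncnn2-c2ccc(Cl)cc2)cc(OC)c1OC` gives > 10000 nM, which is a limit of the assay and not a number. Compound 2 `COc1cc(-c2ncnn2-c2ccccc2)cc(OC)c1OC` gives > 10000 nM, again only a limit. So the starting point is not a measured potency but (the limit of > 10000 nM in this assay, at which 2 of the 2 values shown sit).

Compound 3 `COc1ccc(-n2ncnc2-c2cc(OC)c(OC)c(OC)c2)cc1` brings one change to compound 2: methoxy in place of hydrogen on an aromatic carbon, or phenyl to 4-methoxyphenyl. Among the compounds with values here, the only measured step that bears on this is a step that the two limits leave unreadable from compound 1 to compound 2, and it has no size to carry over. The data therefore fix neither the size nor the direction of the next step. A move towards stronger inhibition in this assay remains possible, and a result at the same limit is about equally likely. The expected change is an at least 2.0-fold lower number from compound 2 to compound 3 (0.30 log units; that floor lies within the scatter), a tentative estimate. For compound 3 the estimated value is 5000 nM, with an expected range from 200 nM to 20000 nM.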

Compound 3, half-maximal inhibitory concentration: > 10000 nM
Compound 3: only a limit was reported (the forecaster's own chance of this, stated with the estimate: 50%); middle value at least 2.0-fold (0.30 log units) from the limit.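

Compound 3 gives > 10000 nM in this assay, which is a limit of the assay and not a number. Within the data shown here, with compound 1 and compound 2 also at limits, no step among the three can be read. The compounds shown leave open how strong each one really is, and whether chloro, hydrogen or methoxy at this position makes any difference: the limit of > 10000 nM in this assay, at which 3 of the 3 values shown sit.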